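The source may report more compounds than this note shows. Statements on the series, on what has been measured and on what is new or still open speak of the compounds shown alone.

Compound 1 `CCCC(C)C(=O)NCC(C)(C)CC1=C(O)C(=O)c2ccccc2C1=O` gives 48100 nM in an ADME assay on Vero cells (Chlorocebus sabaeus) for cytotoxicity, read by reporter gene assay, with a stated time of 4 days; on this read-out higher numbers stand for weaker inhibition and lower numbers for stronger inhibition.
Compound 2 `CCCCCCC(C)C(=O)NCC(C)(C)CC1=C(O)C(=O)c2ccccc2C1=O` gives 15500 nM.
Compound 3 `CCCCCCCCC(=O)NCC(C)(C)CC1=C(O)C(=O)c2ccccc2C1=O` gives 16700 nM.
Compound 4 `CCCCCCCCCCCCCC(=O)NCC(C)(C)CC1=C(O)C(=O)c2ccccc2C1=O` has not yet been measured.

Among the three measured numbers, compound 3 stands second highest. Compound 2 lies nearest to it, and the two are within the usual scatter of each other a 1.1-fold higher number from compound 2 to compound 3 (0.03 log units; within the scatter), so no order between them can be read. Compound 1 lies furthest away, with a step beyond the scatter a 2.9-fold lower number from compound 1 to compound 3 (0.46 log units; beyond the scatter).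

The move from compound 3 to compound 4 is a lengthening of the chain on the amide side: pentyl in place of hydrogen on a saturated chain carbon, eight bonds along the chain from a carbonyl carbon. Within the data shown here, two measured steps bear on this. Lengthening the chain of compound 1 brought a modest lowering a 3.1-fold lower number from compound 1 to compound 2 (0.49 log units; beyond the scatter), and exchanging its shorter branched chain for the longer straight chain of compound 3 did much the same a 2.9-fold lower number from compound 1 to compound 3 (0.46 log units; beyond the scatter). Among the measured compounds shown here, compound 4 carries a still longer chain, so a further modest lowering in this assay is expected, of about a 2.1-fold lower number from compound 3 to compound 4 (0.32 log units; beyond the scatter), although the two measured steps start from compound 1 and no step from a chain as long as that of compound 3 has been seen. Compound 4 is therefore estimated to give around 8000 nM, most likely between 3000 nM and 25000 nM.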

Compound 4, half-maximal inhibitory concentration: 9810 nM
The estimate for compound 4 lay 1.2-fold (0.09 log units) below the measured number, within the range that was stated.
By their numbers in this assay, from the lowest: compounds 4, 2 and 3 (each within the scatter of the next); then compound 1.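

In this assay, among these compounds, this is the first step that starts from a chain as long as the octyl chain of compound 3, and adding pentyl at this place, eight bonds along the chain from a carbonyl carbon, gives a difference that cannot be told from the scatter (a 1.7-fold lower number from compound 3 to compound 4 (0.23 log units; within the scatter)). The step to the octyl chain from the shorter branched chain of compound 1 was larger and could be read (a 2.9-fold lower number from compound 1 to compound 3 (0.46 log units; beyond the scatter)), so the clear difference seen so far belongs only to that shorter starting point, and these four compounds do not show the number falling steadily with every added carbon. Nothing measured here accounts for the smaller size of the newest step.

The compounds shown leave open whether a still longer chain than that of compound 4 would produce a difference that can be read in this assay, or whether the numbers would stay within the scatter. They also leave open how the number would respond to an amine or a carboxylic acid at the far end of the chain, since every chain shown is made of carbon and hydrogen alone.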